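The source may report more compounds than this note shows. Statements on the series, on what has been measured and on what is new or still open speak of the compounds shown alone.

Among the measured compounds shown here, compound 1, with the structure `[N-]=[N+]=Nc1ccc(OCCCNC2CCCC2CCCCCCC(=O)O)cc1`, is the only compound in this set for which a single number is given; a further entry for it carries no number at all. In a functional assay for agonist activity at thromboxane A2 receptor (Homo sapiens) (a higher number here means that more compound is needed for the effect, a lower number that less compound is needed), compound 1 gives 20 uM. A second compound, compound 2, with the structure `O=C(O)CCCCCCC1CCCC1NCCCOc1ccc([N+](=O)[O-])cc1`, has been measured as well, and in this assay compound 2 gives 20 uM; 20 uM (2 entries); the two compounds thus show the same number, with nothing between them beyond the usual scatter.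

The step under consideration leads from compound 1 to compound 3, with the structure `O=C(O)CCCCCCC1CCCC1NCCCOc1ccccc1`. The change is hydrogen in place of azido on an aromatic carbon, in words a hydrogen in place of azido on an aromatic carbon. For the measured compounds named here, no measured step of this kind is available for this series. Since compound 2, which carries a different group at the same place, is no different from compound 1, the expectation is a modest shift at most, if anything toward a higher concentration, and the estimated step from compound 1 to compound 3 is a 1.8-fold higher number from compound 1 to compound 3 (0.24 log units; within the scatter). Compound 3 is accordingly expected to give about 35 uM, within a range from 10 uM to 120 uM.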

Compound 3, concentration for half-maximal effect: 20 uM
Compound 3: the middle estimate sits 1.8-fold (0.24 log units) above what was measured; low and high end bracket the measured number.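

Replacing the azido group with hydrogen gives no change at the digits printed from compound 1 to compound 3 (within the scatter) in this assay, so at this place on an aromatic carbon, para to a large group, the number does not depend on having any substituent at all: phenyl serves as well as 4-azidophenyl. Earlier, azido and nitro could only be compared with each other; now, with compound 2 at 20 uM; 20 uM (2 entries) and compound 3 at 20 uM, the two substituted compounds can also be read against one that carries only hydrogen, and the printed values are the same. The data offer no measured basis for explaining this flat result.

What the compounds shown leave open is whether any group at this place can move the number at all, for instance an amine, a methoxy group or a longer chain, since every value so far is the same. They also leave open whether the shared core responds to a change elsewhere, such as an amide in place of the carboxylic acid.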